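The compounds below may be only part of what the source reports. "The series", "measured", "known", "first", "only" and "open" are said of these compounds alone.

Measured compounds:
compound 1, `COc1cc(C)cc(-c2c(-c3ccnc(-c4ccc(C(C)=O)cc4)c3)cnn2CC#N)c1`: > 100000 nM
compound 2, `Cc1cc(O)cc(-c2nn(CC#N)cc2-c2ccnc(-c3ccc(Oc4ccccc4)cc3)c2)c1`: 35100 nM

In a functional assay on NCI-H522 cells (Homo sapiens) for inhibition, read by sulforhodamine B assay, with a stated time of 48 h (a lower number here means that less compound is tolerated, a higher number that more compound is tolerated), compound 1 gives only a limit of the assay, > 100000 nM. Within the data shown here, compound 2 gives the only plain number in this assay, 35100 nM, and so it is the one point from which a further compound can be judged. The other value, that of compound 1, is the limit of > 100000 nM in this assay, at which 1 of the 2 values shown sits. Compound 3, `Cc1cc(O)cc(-c2nn(CC#N)cc2-c2ccnc(-c3ccc(N(C)C)cc3)c2)c1`, has not yet been measured. It differs from compound 2 in one place: dimethylamino in place of phenoxy on an aromatic carbon. Among the measured compounds shown here, no measured pair in this set shows what such a change does, so neither size nor direction of the step in this assay can be read from the data, and a step that stays within the usual scatter is expected. Compound 3 is therefore estimated at 50000 nM, with a range from 15000 nM to 150000 nM. The expected step of a 1.4-fold higher number from compound 2 to compound 3 (0.15 log units; within the scatter) lies within that scatter.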

Compound 3, concentration lethal to 50% of the cells: 68100 nM
Beside the measured number, compound 3's estimate is 1.4-fold (0.13 log units) below it; measured number inside the range.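

In this assay, placing dimethylamino where phenoxy stood gives a 1.9-fold higher number from compound 2 to compound 3 (0.29 log units; within the scatter). Among these compounds, this is the first exchange in the set that can be read, and it shows that at this position, para to a large group, phenoxy with its six-membered aromatic ring can give way to dimethylamino, which has no ring, without a step beyond the scatter. Nothing at hand explains why the read-out stays within the scatter across this exchange.

The compounds shown leave open whether any group at this position can move the read-out beyond the scatter, for instance a carboxylic acid or a longer alkyl chain. On these data alone, they also rest on this single pair, so it remains unknown whether the same exchange would behave alike on a core with other substituents.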